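Fluoro on the fused ring of compound 1

The source may hold more compounds than are shown below. What is called first, only, known or untested is meant among the compounds shown, and "the series" means these compounds.

For the measured compounds named here, compound 1 `CCn1c(=O)/c(=C2\Sc3ccccc3N2C)s/c1=C\c1ccncc1Nc1ccccc1Cl` gives 750 nM in a functional assay on MCF7 cells (Homo sapiens) for inhibition (on this read-out lower numbers stand for stronger inhibition and higher numbers for weaker inhibition), the second highest of the three numbers measured so far. Going by the values given here, compound 2 `CCn1c(=O)/c(=C2\Sc3ccccc3N2C)s/c1=C\c1ccncc1Nc1cc(C)ccc1C` gives 1700 nM, and the single change between them, 2,5-dimethylphenyl in place of 2-chlorophenyl on a nitrogen on an aromatic ring, brings a 2.3-fold higher number from compound 1 to compound 2 (0.36 log units; beyond the scatter). Compound 3 `CCn1c(=O)/c(=C2\Sc3ccc(C)cc3N2C)s/c1=C\c1ccncc1Nc1ccccc1C` gives 400 nM; it differs from compound 1 in two places, and its number lies within the scatter of that of compound 1.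

Compound 4 `CCn1c(=O)/c(=C2\Sc3cc(F)ccc3N2C)s/c1=C\c1ccncc1Nc1ccccc1Cl` is not yet measured. It differs from compound 1 as follows: fluoro in place of hydrogen on an aromatic carbon. Among the compounds with values here, no measured step touches this part of the shared core, and the one step known concerns a different ring, so nothing in the data points to a direction. The estimate for compound 4 is therefore a 1.1-fold lower number from compound 1 to compound 4 (0.03 log units; within the scatter), and compound 4 is expected to give 700 nM in this assay, within a range from 300 nM to 1700 nM.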

Compound 4, half-maximal inhibitory concentration: 1300 nM
The estimate for compound 4 lay 1.9-fold (0.27 log units) below the measured number; low and high end bracket the measured number.
By their numbers in this assay, from the lowest: compounds 3, 1, 4 and 2 (each within the scatter of the next, the first and the last beyond it).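

For the compounds shown here, this is the first single change measured on the fused part of the shared core, as the earlier step concerned the ring on the nitrogen. In this assay, fluoro in place of hydrogen on this aromatic carbon gives a 1.7-fold higher number from compound 1 to compound 4 (0.24 log units; within the scatter), so this one atom produces no difference that can be told apart from the scatter. Nothing available accounts for this result or gives a reason for its size.

The compounds shown leave open whether a larger or differently built group on this same carbon, such as methoxy, an amine or a carboxylic acid, would move the number beyond the scatter. Compound 3 cannot settle this, since it differs from compound 1 in two places and its ring changes cannot be read apart.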